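The compounds below may be only part of what the source reports. "The series", "measured", "known", "first", "only" and "open" are said of these compounds alone.

Working notes on the series. Within the data shown here, in a physicochemical assay for solubility, read by HPLC, in phosphate buffer, measured as kinetic solubility, at pH 7.4 (a lower number here means a less soluble compound, a higher number a more soluble compound), compound 1 (`NS(=O)(=O)c1ccc(-c2cc(C(=O)C3CC3)nn2-c2ccc(Cl)cc2)cc1`) gives 25600 nM, and compound 2 (`CN(C(=O)c1cc(-c2ccc(S(N)(=O)=O)cc2)n(-c2ccc(Cl)cc2)n1)C1CC1`) gives 99600 nM, the higher of the two numbers so far. Among the measured compounds shown here, the one measured step, a 3.9-fold higher number from compound 1 to compound 2 (0.59 log units; beyond the scatter), comes with cyclopropyl(methyl)amino in place of cyclopropyl on a carbonyl carbon and lies beyond the scatter.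

Compound 3 (`NS(=O)(=O)c1ccc(-c2cc(C(=O)NN3CCCCC3)nn2-c2ccc(Cl)cc2)cc1`) differs from compound 2 at that same carbonyl carbon: (piperidin-1-yl)amino in place of cyclopropyl(methyl)amino on a carbonyl carbon. In words, (piperidin-1-yl)amino stands in place of cyclopropyl(methyl)amino, so a six-membered non-aromatic ring replaces a three-membered ring of carbon only.

For the measured compounds named here, no measured step covers this exchange itself, so the step from compound 1 is the only guide to size. A modest step is expected in this assay, no larger than a 3.9-fold higher number from compound 1 to compound 2 (0.59 log units; beyond the scatter). The expected direction is downward, since compound 2 at 99600 nM holds the higher number, though two compounds support this only weakly. The estimated step is a 2.2-fold lower number from compound 2 to compound 3 (0.35 log units; beyond the scatter). The estimate for compound 3 is 45000 nM, with an expected range from 15000 nM to 110000 nM.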

Compound 3, solubility: 53700 nM
Compound 3: middle estimate off by 1.2-fold (0.08 log units), on the low side; measured number inside the range.
By their numbers in this assay, from the lowest: compound 1; then compounds 3 and 2 (each within the scatter of the next).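

In this assay, (piperidin-1-yl)amino in place of cyclopropyl(methyl)amino on a carbonyl carbon gives a 1.9-fold lower number from compound 2 to compound 3 (0.27 log units; within the scatter), so this exchange does not separate the two compounds, even though the ring, the heavy-atom count and the hydrogen-bond donor count all differ between the groups. Against the cyclopropyl group, (piperidin-1-yl)amino gives a 2.1-fold higher number from compound 1 to compound 3 (0.32 log units; beyond the scatter), so both amino groups shown at this position now carry higher numbers than cyclopropyl, with no compound shown going against that, though the series holds only these three compounds. No measurement shown offers an explanation for these numbers.

Going by these compounds, the exchange from compound 2 to compound 3 alters the ring and the hydrogen-bond donor count together, so the contribution of each stays open. On these data alone, it is also open whether morpholin-4-yl, diethylamino or a hydroxyl group making a carboxylic acid, in place of (piperidin-1-yl)amino on a carbonyl carbon, would stay level with compound 2 and compound 3 or fall toward compound 1.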